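Nitro in Place of Chloro on the Benzyl Ring

The compounds below may be only part of what the source reports. "The series", "measured", "known", "first", "only" and "open" are said of these compounds alone.

Compound 1 `CC(C)(C)c1cc(/C=C/C(=O)NCCC2CCN(Cc3ccccc3)CC2)cc(C(C)(C)C)c1O` and compound 2 `CC(C)(C)c1cc(/C=C/C(=O)NCCC2CCN(Cc3cccc(Cl)c3)CC2)cc(C(C)(C)C)c1O` share one core and differ only in a single substituent of the benzyl ring. In an assay on isolated protein for inhibition of Amine oxidase [flavin-containing] B (Homo sapiens), read by fluorescence, with stated times of 15 min and 20 min (on this read-out lower numbers stand for stronger inhibition and higher numbers for weaker inhibition), compound 1 gives 8500 nM, and in this assay compound 2 gives 8700 nM. The step of a 1.0-fold higher number from compound 1 to compound 2 (0.01 log units; within the scatter) thus lies within the scatter. Among the compounds with values here, compound 2 stands at one end of the two numbers measured, with compound 1 as its only neighbour at a gap within the scatter, so the two cannot be told apart. Compound 3 `CC(C)(C)c1cc(/C=C/C(=O)NCCC2CCN(Cc3cccc([N+](=O)[O-])c3)CC2)cc(C(C)(C)C)c1O` is the next member: nitro in place of chloro on an aromatic carbon. Within the data shown here, the only measured step that bears on this change is the one from compound 1 to compound 2, where chloro replaced hydrogen on an aromatic carbon of the same ring and the number did not move; no step involving a nitro group has been measured. The step of a 1.0-fold lower number from compound 2 to compound 3 (0.01 log units; within the scatter) is therefore expected to stay within the scatter. The estimate for compound 3 in this assay is 8500 nM, with a range from 3500 nM to 20000 nM.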

Compound 3, half-maximal inhibitory concentration: 12500 nM
Compound 3: middle estimate off by 1.5-fold (0.17 log units), on the low side; low and high end bracket the measured number.
By their numbers in this assay, from the lowest: compounds 1, 2 and 3 (each within the scatter of the next).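

In this assay the step is a 1.4-fold higher number from compound 2 to compound 3 (0.16 log units; within the scatter) for nitro in place of chloro, and it is a 1.5-fold higher number from compound 1 to compound 3 (0.17 log units; within the scatter) for nitro in place of hydrogen. Hydrogen, chloro and nitro on this aromatic carbon, meta to a large group, therefore cannot be told apart, and this now holds for an entering group with more heavy atoms and two hydrogen-bond acceptors, which the single chloro step could not show. Nothing measured here offers an explanation for these numbers.

Going by these compounds, it remains open whether an amine or a carboxylic acid on this carbon would move the number beyond the scatter. On these data alone, it is also open whether chloro or nitro on another carbon of the benzyl ring would read the same.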